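This account rests on a few compounds, and the source may have more. Where it says the series, first, only, none or still open, it means among the compounds named here.

The measured compounds are compound 1 `CC(C)c1onc(-c2c(Cl)cccc2Cl)c1COc1ccc(N(C)C(=O)c2ccc(C(=O)O)cc2)c(C(F)(F)F)n1`, compound 2 `CC(C)c1onc(-c2c(Cl)cccc2Cl)c1COc1ccc(NC(=O)c2ccc(C(=O)O)cc2)c(C(F)(F)F)n1` and compound 3 `Cc1nc(OCc2c(-c3c(Cl)cccc3Cl)noc2C(C)C)ccc1N(C)C(=O)c1ccc(C(=O)O)cc1`. In a functional assay on HEK293 cells for agonist activity at Bile acid receptor (Homo sapiens) (a lower number here means that less compound is needed, a higher number that more compound is needed for the effect), compound 1 gives 316 nM, compound 2 gives 474 nM and compound 3 gives 2030 nM.

Compound 2 stands second highest of the three numbers, nearest to compound 1 and furthest from compound 3. The step of a 1.5-fold higher number from compound 1 to compound 2 (0.18 log units; within the scatter) stays within the scatter, so compound 1 and compound 2 cannot be told apart here. The step of a 6.4-fold higher number from compound 1 to compound 3 (0.81 log units; beyond the scatter) is the only one of the two that goes beyond the scatter.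

Compound 4 `CC(C)c1onc(-c2c(Cl)cccc2Cl)c1COc1ccc(NCc2ccc(C(=O)O)cc2)c(C(F)(F)F)n1` is not yet measured. It differs from compound 2 in one place: 4-carboxybenzyl in place of (4-carboxyphenyl)carbonyl on a nitrogen on an aromatic ring. Neither measured step touches this part of the molecule: one changes only the methyl on the amide-type nitrogen, the other a group on an aromatic carbon of the core. For the measured compounds named here, no measured step therefore bears directly on the change from compound 2 to compound 4, and an expectation can rest only on the kind of change itself, which replaces a carbonyl with a methylene. Going by the values given here, the expectation for compound 4 is a 3.2-fold higher number from compound 2 to compound 4 (0.50 log units; beyond the scatter), a loss that no measured step anchors and that carries a wide range. Compound 4 is estimated at 1500 nM, between 400 nM and 6000 nM.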

Compound 4, half-maximal effective concentration: 398 nM
Beside the measured number, compound 4's estimate is 3.8-fold (0.58 log units) above it; measured number below the stated range.
By their numbers in this assay, from the lowest: compounds 1, 4 and 2 (each within the scatter of the next); then compound 3.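

In this assay, the exchange on the nitrogen on an aromatic ring gives a 1.2-fold lower number from compound 2 to compound 4 (0.08 log units; within the scatter), so compound 2 and compound 4 cannot be told apart here. This is the only view of the link itself, since compound 1, compound 2 and compound 3 all carry the carbonyl there. With a methylene in its place, and with the entering group counting 1 hydrogen-bond acceptor where the leaving group counts 2, compound 4 gives 398 nM, which shows that in this assay and on this scaffold the carbonyl of the link is not required for a number in this range; nothing on hand bears on why the number holds across this change.

The compounds shown leave open whether 4-carboxybenzyl behaves the same way when the nitrogen carries a methyl, as in compound 1, or when methyl replaces trifluoromethyl on the aromatic carbon, as in compound 3. They also leave open how far the link can be varied further, for example with a sulfonyl group in place of the methylene or with a longer chain between the nitrogen and the ring.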